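The compounds below may be only part of what the source reports. "The series", "measured", "known", "first", "only" and "open" are said of these compounds alone.

Measured so far in an ADME assay on MT2 cells (Homo sapiens) for cytotoxicity, read by XTT assay, with a stated time of 4 days; a lower number here means that less compound is tolerated, a higher number that more compound is tolerated:
Compound 1 `Cc1ccc(-c2c3c(nc(C)c2[C@H](OC(C)(C)C)C(=O)O)CCN(c2ccccc2)C3)cc1` gives > 40000 nM, a limit of the assay rather than a number.
Compound 2 `Cc1ccc(-c2c3c(nc(C)c2C(OC(C)(C)C)C(=O)O)CCN(S(C)(=O)=O)C3)cc1` gives > 40000 nM, likewise a limit.
Compound 3 `COC(=O)N1CCc2nc(C)c(C(OC(C)(C)C)C(=O)O)c(-c3ccc(C)cc3)c2C1` gives > 40000 nM, also a limit.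

All three values sit at the limit of > 40000 nM in this assay, at which 3 of the 3 values shown sit, so compound 1 stands at the limit, indistinguishable from compound 2 and compound 3 on the numbers shown. Within the data shown here, the only measured step, a step that the two limits leave unreadable from compound 2 to compound 3, changes the group on the ring amine nitrogen but lies between two limits and cannot be sized.

Compound 4 `Cc1ccc(-c2c3c(nc(C)c2[C@H](OC(C)(C)C)C(=O)O)CCN(C(=O)OCc2ccccc2)C3)cc1` differs from compound 1 by benzyloxycarbonyl in place of phenyl on an amine nitrogen in a ring. Among the measured compounds shown here, that is again a change on the ring amine nitrogen, the place where the one measured step gave no readable size. No step beyond the scatter is expected in this assay; compound 4 is expected to remain at the limit, estimated at 40000 nM within 20000 nM to 80000 nM, the expected step being a number no higher from compound 1 to compound 4 (the limit leaves the size open).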

Compound 4, half-maximal cytotoxic concentration: > 40000 nM
Compound 4: a limit, no number; the forecaster's own chance of this, stated with the estimate: 85%; the middle value sits exactly at the limit.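

Compound 1 and compound 4 both stand at a limit in this assay, so no step can be read between them: the limit of > 40000 nM in this assay, at which 4 of the 4 values shown sit.

The compounds shown leave open the actual half-maximal cytotoxic concentration of each, and whether any group on the amine nitrogen in a ring changes it.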